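Cyclopropylcarbonyl for Isopropyl on the Side-Chain Amine

This account rests on a few compounds, and the source may have more. Where it says the series, first, only, none or still open, it means among the compounds named here.

Compound 2 `CC(C)NCCS(=O)(=O)NC(=O)c1ccc(Nc2nc(NC3(c4ccc(Cl)cc4)CC3)nc(OCC(F)(F)F)n2)cc1` gives 89% in an ADME assay on microsomes from liver (Homo sapiens) for metabolic stability, with a stated time of 10 min (on this read-out higher numbers stand for a more stable compound and lower numbers for a less stable compound), the lower of the two numbers shown, while compound 1 `O=C(NS(=O)(=O)c1ccc(F)cc1)c1ccc(Nc2nc(NC3(c4ccc(Cl)cc4)CC3)nc(OCC(F)(F)F)n2)cc1` stands at 100%; the step of a number 11 percentage points lower from compound 1 to compound 2 (beyond the scatter) is the only one measured. Compound 3 `O=C(NS(=O)(=O)CCNC(=O)C1CC1)c1ccc(Nc2nc(NC3(c4ccc(Cl)cc4)CC3)nc(OCC(F)(F)F)n2)cc1` differs from compound 2 by cyclopropylcarbonyl in place of isopropyl on an amine nitrogen. Within the data shown here, the one measured step altered the group on a sulfonyl sulfur, a different part of the molecule, so it bears only loosely on this change, and it was itself modest. Compound 3 is therefore expected to stay close to compound 2, with an estimated step of a number 1 percentage points lower from compound 2 to compound 3 (within the scatter) within the scatter. The estimated value for compound 3 is 88%, in a range from 70% to 100%.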

Compound 3, percent of the compound remaining: 90%
For compound 3 the middle estimate is 2 percentage points below the measured one; measured number inside the range.
By their numbers in this assay, from the lowest: compounds 2, 3 and 1 (each within the scatter of the next, the first and the last beyond it).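

On the amine nitrogen, cyclopropylcarbonyl in place of isopropyl gives a number 1 percentage points higher from compound 2 to compound 3 (within the scatter) in this assay, so this read-out does not separate the two groups at this position. With 2-((cyclopropylcarbonyl)amino)ethyl in place of 4-fluorophenyl on the sulfonyl sulfur, the result is a number 10 percentage points lower from compound 1 to compound 3 (within the scatter) and the step stays inside the scatter, whereas the earlier step with 2-(isopropylamino)ethyl lay beyond it. Nothing available explains these numbers. Open, on these data alone, is how a longer chain between the sulfonyl sulfur and the amine nitrogen would read, or a carboxylic acid or a sulfonamide on that nitrogen.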